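The source may report more compounds than this note shows. Statements on the series, on what has been measured and on what is new or still open speak of the compounds shown alone.

The series shares the core of compound 1, `Oc1ccc(Cn2cccn2)c2cccnc12`, and in a functional assay on MV4-11 cells (Homo sapiens) for antiproliferative activity, read by luminescence, with a stated time of 72 h (a lower number here means a stronger inhibitor, a higher number a weaker inhibitor), compound 1 gives 1600 nM. Compound 2, `CC(C)(CCl)C(=O)Oc1ccc(Cn2ccnc2)c2cccnc12`, carries an acyl group on that core; in this assay compound 2 gives 8900 nM, the highest of the two numbers recorded, and its nearest neighbour, compound 1, sits at a lower number by a gap that lies beyond the usual scatter. Compound 3, `Cc1cc2ncn(Cc3ccc(O)c4ncccc34)c2cc1C`, has in this assay the entry "not determined" (no result reported), so no result is reported for it. Compound 4, `CC(C)(C)OC(=O)Oc1ccc(Cn2ccnc2)c2cccnc12`, is not yet measured. It differs from compound 2 in one place: tert-butoxy in place of 1-(chloromethyl)-1-methylethyl on a carbonyl carbon. Among the measured compounds shown here, no pair of measured compounds shows this change, so nothing in the data sets its size or direction. The step of a 1.3-fold lower number from compound 2 to compound 4 (0.10 log units; within the scatter) is expected to be small, within or only just beyond the scatter, with no clear direction favoured. For compound 4 the expected value in this assay is 7000 nM, with a range from 2500 nM to 20000 nM.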

Compound 4, half-maximal inhibitory concentration: 11500 nM
Compound 4: middle estimate off by 1.6-fold (0.22 log units), on the low side; low and high end bracket the measured number.
By their numbers in this assay, from the lowest: compound 1; then compounds 2 and 4 (each within the scatter of the next).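

In this assay, tert-butoxy in place of 1-(chloromethyl)-1-methylethyl on a carbonyl carbon gives a 1.3-fold higher number from compound 2 to compound 4 (0.11 log units; within the scatter), the first measured size for this change. The two groups have the same heavy-atom count, and tert-butoxy brings one hydrogen-bond acceptor where 1-(chloromethyl)-1-methylethyl has none, yet this read-out does not separate compound 2 from compound 4. No measurement at hand offers an explanation for this result.

Still open, on these data alone, is whether an amine or a longer chain on that carbonyl carbon would take the number beyond the scatter. Also open, as far as these compounds go, is whether the same exchange would stay this small on the core of compound 1.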